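4-Methylbenzyl to 3-fluorobenzyl: notes on the next step

The source may report more compounds than this note shows. Statements on the series, on what has been measured and on what is new or still open speak of the compounds shown alone.

Within the data shown here, in a functional assay on Jurkat cells (Homo sapiens) (a lower number here means a stronger inhibitor, a higher number a weaker inhibitor), compound 1 (`C[C@H](NC(=O)C(=O)NCc1ccc(Cl)cc1)C(=O)N[C@@H](CC(=O)O)C(=O)COc1c(F)c(F)cc(F)c1F`) stands at 8.4 nM while compound 2 (`C[C@H](NC(=O)C(=O)NCC1(c2ccccc2)CC1)C(=O)N[C@@H](CC(=O)O)C(=O)COc1c(F)c(F)cc(F)c1F`) stands at 27 nM and compound 3 (`Cc1ccc(CNC(=O)C(=O)N[C@@H](C)C(=O)N[C@@H](CC(=O)O)C(=O)COc2c(F)c(F)cc(F)c2F)cc1`) at 50 nM on the numbers so far. Compound 3 therefore sits level with compound 2 and apart from compound 1, as two steps show: a 1.9-fold higher number from compound 2 to compound 3 (0.27 log units; within the scatter) and a 6.0-fold higher number from compound 1 to compound 3 (0.77 log units; beyond the scatter) in this series.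

Compound 4 (`C[C@H](NC(=O)C(=O)NCc1cccc(F)c1)C(=O)N[C@@H](CC(=O)O)C(=O)COc1c(F)c(F)cc(F)c1F`) carries 3-fluorophenyl in place of 4-methylphenyl on a saturated chain carbon bound to an amide-type nitrogen. Among the measured compounds shown here, no measured compound has fluorine on this ring. The nearest guide is the methyl and chloro exchange between compound 1 and compound 3 (a 6.0-fold higher number from compound 1 to compound 3 (0.77 log units; beyond the scatter)), which, read in reverse, points towards a lower number. That exchange involves 4-chlorophenyl rather than 3-fluorophenyl, so only part of its size is carried over. The step expected in this assay is a 2.3-fold lower number from compound 3 to compound 4 (0.36 log units; beyond the scatter) and it may barely clear the scatter. Compound 4 is estimated at 22 nM with an expected range from 7 nM to 60 nM in this read-out.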

Compound 4, half-maximal inhibitory concentration: 106 nM
For compound 4 the middle estimate is 4.8-fold (0.68 log units) below the measured one, and the stated range ends below it.
By their numbers in this assay, from the lowest: compound 1; then compounds 2 and 3 (each within the scatter of the next); then compound 4.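

Among these compounds, a halogen on this ring does not by itself give a low number in this assay: 3-fluorobenzyl gives a 13-fold higher number from compound 1 to compound 4 (1.10 log units; beyond the scatter) when set against 4-chlorobenzyl, the largest step so far. It also loses to the non-halogenated groups, with a 2.1-fold higher number from compound 3 to compound 4 (0.33 log units; beyond the scatter) and a 3.9-fold higher number from compound 2 to compound 4 (0.59 log units; beyond the scatter), which makes compound 4 the weakest of the four and shows that the low number of compound 1 depends on more than the presence of a halogen. No supporting data are available to explain this rise.

Because compound 1 and compound 4 differ in both the halogen and its ring position, the two contributions remain unseparated. 4-Fluorobenzyl and 3-chlorobenzyl would each change only one of them, and the compounds shown do not say how either would compare.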